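This account rests on a few compounds, and the source may have more. Where it says the series, first, only, none or still open, it means among the compounds named here.

In a functional assay on HL-60 cells (Homo sapiens) for cytotoxicity, read by MTT assay, with a stated time of 48 h (on this read-out higher numbers stand for weaker inhibition and lower numbers for stronger inhibition), three compounds with a shared core have been measured. Compound 1 `Fc1cccc(-c2nc(Nc3ccccc3)c3cc(F)ccc3n2)c1` gives 48300 nM, a true number near the top of the range seen here. Compound 2 `Fc1cccc(-c2nc(Nc3cccc(Br)c3)c3cc(F)ccc3n2)c1` gives > 50000 nM, which is a limit and not a number. Compound 3 `Oc1cccc(Nc2nc(-c3cccc(F)c3)nc3ccc(F)cc23)c1` gives > 50000 nM, which is also a limit. As far as these compounds go, that places compound 3 at the limit of > 50000 nM in this assay, at which 2 of the 3 values shown sit, so its exact value is unknown.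

Compound 4 `Nc1ccc(Nc2nc(-c3cccc(F)c3)nc3ccc(F)cc23)cc1` has 4-aminophenyl in place of 3-hydroxyphenyl on a nitrogen on an aromatic ring. For the measured compounds named here, no measured step makes this exact swap. The nearest evidence comes from single changes to the same group, namely an at least 1.0-fold higher number from compound 1 to compound 2 (0.01 log units; that floor lies within the scatter) and an at least 1.0-fold higher number from compound 1 to compound 3 (0.01 log units; that floor lies within the scatter). Neither shows a change beyond the scatter, and a step that the two limits leave unreadable from compound 2 to compound 3 adds nothing because the two values are both limits.

None of these steps gives a reason to expect a large move in this assay, so no change beyond the scatter is expected. The expected result is an at least 1.2-fold lower number from compound 3 to compound 4 (0.09 log units; that floor lies within the scatter), and the assay may well report only a limit again. The estimate for compound 4 is 40000 nM, with an expected range from 12000 nM to 50000 nM.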

Compound 4, half-maximal inhibitory concentration: > 50000 nM
Compound 4: no number, only a limit; the forecaster's own chance of this, stated with the estimate: 50%; at least 1.2-fold (0.09 log units) between middle value and limit.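

In this assay compound 4 gives > 50000 nM, which is a limit and not a number. For the compounds shown here, the data show an at least 1.0-fold higher number from compound 1 to compound 4 (0.01 log units; that floor lies within the scatter), so an amino group on this ring, like the bromo and hydroxy groups before it, produces no step that can be told apart from the scatter when set against the plain phenyl ring of compound 1. The steps linking compound 4 to compound 2 and compound 3 cannot be read, since both ends of each are limits, and swapping 3-hydroxyphenyl for 4-aminophenyl on this nitrogen gives one more result of the same kind: the limit of > 50000 nM in this assay, at which 3 of the 4 values shown sit.

The compounds shown leave open whether any group at this place can give a clearly lower number than compound 1, which, at 48300 nM, holds the only true number in the set. As far as these compounds go, it also remains open what a carboxylic acid, or a longer chain ending in an amine, would do on this ring in the same cell test.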